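The source may report more compounds than this note shows. Statements on the series, on what has been measured and on what is new or still open speak of the compounds shown alone.

Measured to date:
compound 1 `COc1cc(-c2cc(/C=C/C(=O)c3ccc(N)cc3)[nH]n2)cc(OC)c1OC`, 3060 nM in a functional assay on SK-MEL-5 cells (Homo sapiens) for inhibition, read by sulforhodamine B assay, with a stated time of 48 h; on this read-out lower numbers stand for stronger inhibition of growth and higher numbers for weaker inhibition of growth;
compound 2 `COc1ccc(-c2cc(/C=C/C(=O)c3ccc(N)cc3)[nH]n2)cc1OC`, 11500 nM;
compound 3 `COc1cc(C(=O)/C=C/c2cc(-c3cc(OC)c(OC)c(OC)c3)n[nH]2)cc(OC)c1OC`, 2940 nM.

Compound 1 stands second highest of the three numbers; its nearest neighbour is compound 3, and the two lie within the scatter of each other, while compound 2 lies furthest away. Going by the values given here, the only single-place step recorded, a 3.8-fold higher number from compound 1 to compound 2 (0.57 log units; beyond the scatter), concerns the aryl ring on the other side of the shared core, not the carbonyl side.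

Compound 4 `COc1cc(-c2cc(/C=C/C(=O)c3ccc(F)c(F)c3)[nH]n2)cc(OC)c1OC` differs from compound 1 as follows: 3,4-difluorophenyl in place of 4-aminophenyl on a carbonyl carbon. Among the compounds with values here, no measured step touches this position, so nothing recorded bears directly on it. Pending the measurement, compound 4 is expected to give 4000 nM (range 1500 nM to 12000 nM), an estimated step of a 1.3-fold higher number from compound 1 to compound 4 (0.12 log units; within the scatter), not clearly beyond the scatter.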

Compound 4, concentration for total growth inhibition: 6410 nM
Compound 4: middle estimate off by 1.6-fold (0.20 log units), on the low side; measured number inside the range.
By their numbers in this assay, from the lowest: compounds 3 and 1 (each within the scatter of the next); then compounds 4 and 2 (each within the scatter of the next).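

The carbonyl side of the series now has its first reading: 3,4-difluorophenyl in place of 4-aminophenyl on the carbonyl carbon gives a 2.1-fold higher number from compound 1 to compound 4 (0.32 log units; beyond the scatter), so growth inhibition responds to a change at this position. The entering group has no hydrogen-bond donors or acceptors, but this single pair cannot separate that difference from the loss of the amine or the gain of fluorine. No measurement at hand accounts for the step.

Still open, from the compounds shown here alone, is how a plain phenyl, a 4-fluorophenyl or a 4-dimethylaminophenyl on the same carbonyl carbon would read against compound 1 and compound 4.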